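Bromine on the Indole Ring of a Hydroxamate

The source may report more compounds than this note shows. Statements on the series, on what has been measured and on what is new or still open speak of the compounds shown alone.

Three compounds have been measured in a functional assay on NFF cells (Homo sapiens) for antiproliferative activity; a higher number here means a weaker inhibitor, a lower number a stronger inhibitor:

Compound 1, `CN(C)c1ccc(C(=O)NC(CCCCCC(=O)NO)C(=O)NC2CCCc3ccccc32)cc1`, gives 1810 nM.
Compound 2, `O=C(CCCCC[C@H](NC(=O)c1cc2ccccc2[nH]1)C(=O)NCc1ccccc1)NO`, gives 1260 nM.
Compound 3, `O=C(CCCCC[C@H](NC(=O)CCCc1c[nH]c2ccccc12)C(=O)NCc1ccccc1)NO`, gives 7030 nM.

All three share a hydroxamic acid on a six-carbon chain and a benzyl or tetralin amide, and differ in the group attached to the amide nitrogen. Compound 2 carries the lowest number of the three. Its gap to compound 1 lies within the usual scatter, so the two cannot be ordered, while compound 3 stands clearly higher, beyond the scatter.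

Compound 4, `O=C(CCCCC[C@H](NC(=O)c1cc2c(Br)cccc2[nH]1)C(=O)NCc1ccccc1)NO`, has not yet been measured. It differs from compound 2 in one place: bromo in place of hydrogen on an aromatic carbon. Put one bond further out, the change reads 1H-indol-2-yl to 4-bromo-1H-indol-2-yl, on the six-membered aromatic ring of carbon only within the fused two-ring system.

For the measured compounds named here, no measured pair shows what a bromine at this place does, so the step can only be guessed. The expected step of a 1.3-fold lower number from compound 2 to compound 4 (0.10 log units; within the scatter) in this assay is small, without a clear direction, and likely within the scatter. For compound 4 the estimated value in this assay is 1000 nM, with a range from 400 nM to 3200 nM.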

Compound 4, half-maximal inhibitory concentration: 1940 nM
Compound 4: the middle estimate sits 1.9-fold (0.29 log units) below what was measured; the range from low to high includes it.
By their numbers in this assay, from the lowest: compounds 2, 1 and 4 (each within the scatter of the next); then compound 3.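

Placing a bromo group on the aromatic carbon, the change from 1H-indol-2-yl to 4-bromo-1H-indol-2-yl, gives in this assay a 1.5-fold higher number from compound 2 to compound 4 (0.19 log units; within the scatter). For the compounds shown here, this is the first pair here that differs in only one place, and it shows that this position can carry a bromine without a difference this assay can resolve, so compound 2 and compound 4 cannot be ordered. Nothing at hand explains this outcome or shows how the bromine acts at this position.

A single pair cannot show whether the result belongs to bromine itself or would hold for any group at this position, so a fluorine, a methoxy group, an amine or a carboxylic acid on the same carbon would each be a real test. Going by these compounds, it also remains open whether bromine on another carbon of the same ring, or on the side group of compound 3, would stay just as close to its parent compound.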